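Bromo for azido on the carbonyl-bound chain carbon

A few compounds are considered here, and "the series" means these few. Any claim that something is new, unique, unknown or untested is made for them only; others in the source may bear on it.

Measured so far:
compound 1, `COc1ccc(CN(C(=O)CCl)c2cc(OC)c(OC)c(OC)c2)cc1O`: 210 nM
compound 2, `COc1ccc(CN(C(=O)CN=[N+]=[N-])c2cc(OC)c(OC)c(OC)c2)cc1O`: 160 nM

In a functional assay on KYSE-450 cells (Homo sapiens) for inhibition, read by MTT assay, with a stated time of 48 h (on this read-out higher numbers stand for weaker inhibition and lower numbers for stronger inhibition), compound 1 gives 210 nM, and compound 2 gives 160 nM. Going by the values given here, the single step in hand, a 1.3-fold lower number from compound 1 to compound 2 (0.12 log units; within the scatter), lies within the scatter, so compound 2 and compound 1 cannot be told apart on these two numbers; compound 2 simply sits at the end of a two-member series whose whole span is within the usual scatter.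

Compound 3, `COc1ccc(CN(C(=O)CBr)c2cc(OC)c(OC)c(OC)c2)cc1O`, differs from compound 2 by bromo in place of azido on a saturated chain carbon bound to a carbonyl carbon. Among the compounds with values here, no measured pair shows bromo against azido or bromo against chloro, so the only bearing comes from the chloro-to-azido step a 1.3-fold lower number from compound 1 to compound 2 (0.12 log units; within the scatter), which was small. With a second exchange of a one-heavy-atom group for the azido group at the same place, nothing in the data points to a step beyond the scatter in either direction.

Compound 3 is therefore expected to give about 180 nM in this assay, the estimated range running from 80 nM to 400 nM. The expected step from compound 2 is a 1.1-fold higher number from compound 2 to compound 3 (0.05 log units; within the scatter), within the scatter.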

Compound 3, half-maximal inhibitory concentration: 120 nM
Compound 3: the middle estimate sits 1.5-fold (0.18 log units) above what was measured; the measured number falls inside the stated range.
By their numbers in this assay, from the lowest: compounds 3, 2 and 1 (each within the scatter of the next).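

In this assay the saturated chain carbon bound to a carbonyl carbon now carries three different groups, and the two new steps, a 1.3-fold lower number from compound 2 to compound 3 (0.12 log units; within the scatter) and a 1.8-fold lower number from compound 1 to compound 3 (0.24 log units; within the scatter), add to the earlier chloro-to-azido step without leaving the usual scatter. Chloro, azido and bromo therefore cannot be told apart at this place on the present numbers, even though the exchange of azido for bromo replaces 3 heavy atoms with 1 heavy atom, and the bromo-for-chloro pair, absent until now, gives the same reading. Nothing available explains this result or assigns any property to these groups.

The compounds shown leave open whether a group of another kind at this place, such as a hydroxyl, an amine or a carboxylic acid, or a plain hydrogen in place of the bromo, would give a step beyond the scatter. They also leave open whether a longer chain carrying the bromo between it and the carbonyl carbon would read the same way, as all three compounds share one chain length and one core.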